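The source may report more compounds than this note shows. Statements on the series, on what has been measured and on what is new or still open speak of the compounds shown alone.

The series shares one core, varied at a double-bonded chain carbon. Compound 1 `COc1ccc(/C=C/C(=O)c2cc3ccc(OCc4cccc(OC)c4)cc3oc2=O)cc1` has been tested in a functional assay on MCF7 cells (Homo sapiens) for cytotoxicity, read by MTT assay, with a stated time of 72 h; on this read-out lower numbers stand for stronger inhibition and higher numbers for weaker inhibition; there compound 1 reaches only > 100000 nM, which is a limit of the assay and not a number, as the limit of > 100000 nM in this assay, at which 1 of the 2 values shown sits, records. Compound 2 `COc1cccc(COc2ccc3cc(C(=O)/C=C/c4ccc(Cl)cc4Cl)c(=O)oc3c2)c1` carries a 2,4-dichlorophenyl group at that carbon; in this assay compound 2 stands at "not determined" (no result reported), so no number exists for it. Among the measured compounds shown here, the only further value in the set is the limit recorded for compound 1. Compound 3 `COc1cccc(COc2ccc3cc(C(=O)/C=C/c4ccc(C)cc4)c(=O)oc3c2)c1` differs from compound 2 by a single change, (4-methylphenyl in place of 2,4-dichlorophenyl on a double-bonded chain carbon bound to a double-bonded chain carbon). For the measured compounds named here, with no measured step anywhere in the set, neither a size nor a direction can be read for this change in this assay, and the starting point itself is blank. The expectation for compound 3 rests only on the limit seen for compound 1. Compound 3 is expected to give about 80000 nM in this assay, within an estimated range of 20000 nM to 300000 nM, and quite possibly only a limit again.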

Compound 3, half-maximal inhibitory concentration: > 50000 nM
Compound 3: no number, only a limit; the forecaster's own chance of this, stated with the estimate: 65%; the middle value is on the limit's open side.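

In this assay compound 3 gives > 50000 nM, which is a limit and not a number. Compound 1 also stands at a limit, and no step can be read between compound 1 and compound 3. Going by these compounds, whether methyl in place of methoxy on an aromatic carbon changes the read-out stays open.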